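The compounds below may be only part of what the source reports. "The series", "measured", "known", "first", "only" and "open" are said of these compounds alone.

Measured in a functional assay on PC-3 cells (Homo sapiens) for cytotoxicity, read by sulforhodamine B assay, with a stated time of 48 h; on this read-out lower numbers stand for stronger inhibition and higher numbers for weaker inhibition:

- compound 1 `C[C@H]1CC[C@@H]2[C@@H](OC(=O)[C@]23CC(c2c(Cl)cccc2Cl)=NO3)[C@]2(C)C(=O)C=C[C@@]12O` gives 56000 nM
- compound 2 `C[C@H]1CC[C@@H]2[C@@H](OC(=O)[C@]23CC(c2ccccc2)=NO3)[C@]2(C)C(=O)C=C[C@@]12O` gives 46000 nM

Compound 2 stands level with compound 1 on these numbers, since the two lie within the scatter of each other and cannot be ranked. Among the measured compounds shown here, the only measured step, a 1.2-fold lower number from compound 1 to compound 2 (0.09 log units; within the scatter), puts phenyl in place of 2,6-dichlorophenyl and stays within the scatter.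

The next structure is compound 3 `C[C@H]1CC[C@@H]2[C@@H](OC(=O)[C@]23CC(c2ccc(N(C)C)cc2)=NO3)[C@]2(C)C(=O)C=C[C@@]12O`, which turns the phenyl of compound 2 into 4-(dimethylamino)phenyl. It has dimethylamino in place of hydrogen on an aromatic carbon, para to a large group (dimethylamino in place of hydrogen on an aromatic carbon).

That one measured step bears on this change only loosely. It alters the same aryl group, but no measured compound carries dimethylamino, so the effect of this group is not shown directly. With so little evidence, the expectation is for no clear change beyond the scatter, in either direction. The expected step is small (a 1.2-fold lower number from compound 2 to compound 3 (0.08 log units; within the scatter)). Compound 3 is estimated at 38000 nM, with an expected range from 13000 nM to 95000 nM.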

Compound 3, half-maximal inhibitory concentration: 6300 nM
Estimate against measurement, compound 3: 6.0-fold (0.78 log units) above; measured number outside the range, below it.
By their numbers in this assay, from the lowest: compound 3; then compounds 2 and 1 (each within the scatter of the next).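

The aryl group on the carbon with a double bond to nitrogen turns out to be a place where the number in this assay can move, which the earlier pair could not show, since swapping 2,6-dichlorophenyl for phenyl stayed within the scatter. Adding dimethylamino in place of hydrogen on an aromatic carbon, para to a large group, gives a 7.3-fold lower number from compound 2 to compound 3 (0.86 log units; beyond the scatter), the first step in this set that lies beyond the scatter, and the comparison with the dichlorinated aryl group gives an 8.9-fold lower number from compound 1 to compound 3 (0.95 log units; beyond the scatter), a similar picture of a modest gain in inhibition of these cells. Nothing available explains why this single group changes the number so much, so the step stands as an observation only.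

The compounds shown leave open whether the gain belongs to dimethylamino itself or would also appear with a plain amino group, a methoxy group or the longer diethylamino group at the same place. They also leave open what dimethylamino would do on another carbon of the same aromatic ring.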